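The source may hold more compounds than are shown below. What is called first, only, known or untested is meant among the compounds shown, and "the series" means these compounds.

Working notes on the series. In a functional assay on A2780 cells (Homo sapiens) for antiproliferative activity, read by CellTiter-Glo, with a stated time of 4 days (on this read-out lower numbers stand for stronger inhibition and higher numbers for weaker inhibition), compound 1 `C[C@H](NC(=O)C1CCOCC1)c1ccc(NC(=O)[C@H]2C[C@@H]2c2cccnc2)cc1`, with oxan-4-yl on the carbonyl carbon, gives 3 nM. Compound 2 `C[C@H](NC(=O)[C@@H]1CCCN1C)c1ccc(NC(=O)[C@H]2C[C@@H]2c2cccnc2)cc1`, with 1-methylpyrrolidin-2-yl there, gives 1 nM, and compound 3 `C[C@H](NC(=O)c1ccccc1)c1ccc(NC(=O)[C@H]2C[C@@H]2c2cccnc2)cc1`, with phenyl there, gives 1 nM. Compound 3 is therefore level with compound 2, and together they hold the lowest of the three numbers.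

The next structure is compound 4 `C[C@H](NC(=O)c1ccc(F)cc1)c1ccc(NC(=O)[C@H]2C[C@@H]2c2cccnc2)cc1`, which differs from compound 3 as follows: fluoro in place of hydrogen on an aromatic carbon. In words, this is fluoro in place of hydrogen on an aromatic carbon, para to a large group.

Among the compounds with values here, no measured step makes this change. The nearest evidence comes from swaps of the whole group on the same carbonyl carbon. Two are modest, a 3.0-fold lower number from compound 1 to compound 2 (0.48 log units; beyond the scatter) and a 3.0-fold lower number from compound 1 to compound 3 (0.48 log units; beyond the scatter), while the third stays within the scatter, no change at the digits printed from compound 2 to compound 3 (within the scatter). Each of these replaces an entire group, whereas compound 4 keeps the phenyl ring and exchanges a single hydrogen, so a smaller effect than the modest steps is expected. No step beyond the scatter is anticipated in this assay, and the data favour no direction.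

The expected outcome is no change at the digits printed from compound 3 to compound 4 (within the scatter).

For compound 4 the estimated value is 1 nM, with an expected range of 0.4 nM to 3 nM.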

Compound 4, half-maximal inhibitory concentration in the A2780 assay: 2 nM
Beside the measured number, compound 4's estimate is 2.0-fold (0.30 log units) below it, within the range that was stated.
By their numbers in the A2780 assay, from the lowest: compounds 2, 3, 4 and 1 (each within the scatter of the next, the first and the last beyond it).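

Fluoro on an aromatic carbon, para to a large group, is the only change shown on the phenyl ring itself, and in the A2780 assay it stays within the scatter, with a 2.0-fold higher number from compound 3 to compound 4 (0.30 log units; within the scatter); the 4-fluorophenyl group is also within the scatter of the two other groups on the carbonyl carbon, with a 2.0-fold higher number from compound 2 to compound 4 (0.30 log units; within the scatter) and a 1.5-fold lower number from compound 1 to compound 4 (0.18 log units; within the scatter), although compound 1 and compound 3 are printed as beyond the scatter of each other. In a physicochemical assay for solubility, at pH 6.8 (on this read-out lower numbers stand for lower solubility and higher numbers for higher solubility), compound 3 gives < 4000 nM, which is a limit of the assay and not a number: the limit of < 4000 nM in the physicochemical assay, at which 1 of the 2 values shown sits. In the physicochemical assay compound 4 gives 6000 nM. In the physicochemical assay the step reads an at least 1.5-fold higher number from compound 3 to compound 4 (0.17 log units; that floor lies within the scatter), so its true size stays unread.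

The compounds shown leave open how a chloro, methoxy or nitrile group on this same aromatic carbon would read in the A2780 assay. Also open, on these data alone, is whether an amine or a carboxylic acid at this place would give a step beyond the scatter in the A2780 assay or in the physicochemical assay.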